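Notes on compounds 1 to 4 in a growth assay

The compounds below may be only part of what the source reports. "The series", "measured", "known", "first", "only" and "open" are said of these compounds alone.

Measured so far in a functional assay on PC-3 cells (Homo sapiens) for cytotoxicity, read by MTT assay, with a stated time of 72 h; a lower number here means a stronger inhibitor of growth, a higher number a weaker inhibitor of growth:
compound 1 `C[Se]/C(=N\C(=O)c1cccs1)NC(=O)c1cccs1` gives 63000 nM
compound 2 `C[Se]/C(=N\C(=O)c1cnc2ccccc2c1)NC(=O)c1cnc2ccccc2c1` gives 43600 nM
compound 3 `CS/C(=N\C(=O)c1cnc2ccccc2c1)NC(=O)c1cnc2ccccc2c1` gives > 100000 nM

The value of compound 3 is a limit of this assay and not a number. Compound 3 is the single one of the three at the limit of > 100000 nM in this assay, at which 1 of the 3 values shown sits. For the measured compounds named here, compound 1 and compound 2 both return numbers, and no step is drawn between them; their values simply stand side by side.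

Going by the values given here, the one measured step that touches the carbon with a double bond to nitrogen is an at least 2.2-fold higher number from compound 2 to compound 3 (0.36 log units; beyond the scatter), where the methylsulfanyl group replaced the methylselanyl group and the number rose beyond the scatter.

Compound 4 `O=C(/N=C(/NC(=O)c1cnc2ccccc2c1)[Se]Cc1ccccc1)c1cnc2ccccc2c1` differs from compound 3 as follows: a group of 8 heavy atoms (7 carbon, 1 selenium; one six-membered aromatic ring of carbon only) in place of a group of 2 heavy atoms (1 carbon, 1 sulfur; no ring), on a carbon with a double bond to nitrogen. Among the compounds with values here, the return of selenium at this carbon mirrors the step from compound 2 to compound 3, only reversed, so a lower number is expected; the benzyl group in place of methyl has no measured counterpart here, and its effect remains open. In this assay the step of an at least 2.5-fold lower number from compound 3 to compound 4 (0.39 log units; beyond the scatter) is therefore expected to fall, with the reversal of an at least 2.2-fold higher number from compound 2 to compound 3 (0.36 log units; beyond the scatter) as the reason. For compound 4 the estimate is 40000 nM, within a range from 10000 nM to 150000 nM.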

Compound 4, concentration for total growth inhibition: > 100000 nM
Compound 4 gave a limit, no number (the forecaster's own chance of this, stated with the estimate: 25%); middle value at least 2.5-fold (0.39 log units) away from the limit.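

In this assay the value of compound 4 is a limit of the assay and not a number, and the step from compound 3 to compound 4, which joins two limits, cannot be read. For the compounds shown here, the informative comparison keeps selenium in place: phenyl in place of hydrogen on a saturated chain carbon bound to a selenium atom gives an at least 2.2-fold higher number from compound 2 to compound 4 (0.36 log units; beyond the scatter), so selenium on the carbon with a double bond to nitrogen does not by itself secure a measured number, and the earlier compounds showed an upward change at this carbon only for the exchange of methylselanyl for methylsulfanyl. The top of the measurable range now holds a second compound of the shared core: the limit of > 100000 nM in this assay, at which 2 of the 4 values shown sit.

From the compounds shown here alone, how much of the rise belongs to the aromatic ring and how much to the greater length of the group stays open, and an ethyl group or a longer saturated chain on the selenium would separate the two. Also open, going by these compounds, is whether the same phenyl change on the core of compound 1, which gives 63000 nM, would move its number in the same direction.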